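A few compounds are considered here, and "the series" means these few. Any claim that something is new, unique, unknown or untested is made for them only; others in the source may bear on it.

Measured so far in an assay on isolated protein for activation of cGMP-dependent protein kinase 1 (Homo sapiens), read by ADP-Glo, with stated times of 30 min and 2 h, in the presence of a further agent that is not named here; a lower number here means that less compound is needed, a higher number that more compound is needed for the effect:

compound 1, `O=C(O)C12CC(CN3CCC[C@H](O[C@H](CO)c4cc(Cl)cc(Cl)c4)[C@@H]3c3ccccc3)(C1)C2`: 12000 nM
compound 2, `O=C(O)c1ccc(CN2CCC[C@H](O[C@H](CO)c3cc(Cl)cc(Cl)c3)[C@@H]2c2ccccc2)c([N+](=O)[O-])c1`: 520 nM

Going by the values given here, compound 2 holds the lowest of the two numbers so far; its nearest neighbour is compound 1, and the step of a 23-fold lower number from compound 1 to compound 2 (1.36 log units; beyond the scatter) stands beyond the scatter, so the two are clearly apart.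

The next compound, compound 3, is `Nc1cc(C(=O)O)ccc1CN1CCC[C@H](O[C@H](CO)c2cc(Cl)cc(Cl)c2)[C@@H]1c1ccccc1`. Against compound 2 the difference is amino in place of nitro on an aromatic carbon — amino in place of nitro on an aromatic carbon, ortho to a large group and meta to the carboxy group. Among the compounds with values here, the only measured step, a 23-fold lower number from compound 1 to compound 2 (1.36 log units; beyond the scatter), exchanges the whole group on the saturated chain carbon bound to the amine nitrogen in the ring and does not touch a substituent on the aromatic ring; it therefore gives no direct reading on the present change. With nothing in the series to anchor a shift in either direction, the expectation for this assay is a step from compound 2 to compound 3 of no more than the scatter, a 1.2-fold higher number from compound 2 to compound 3 (0.06 log units; within the scatter), given with a wide range. Compound 3 is accordingly estimated at 600 nM, expected to fall between 200 nM and 1800 nM.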

Compound 3, half-maximal effective concentration in the cGMP-dependent protein kinase 1 assay: 290 nM
Estimate against measurement, compound 3: 2.1-fold (0.32 log units) above, within the range that was stated.
By their numbers in the cGMP-dependent protein kinase 1 assay, from the lowest: compounds 3 and 2 (each within the scatter of the next); then compound 1.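

In the cGMP-dependent protein kinase 1 assay compound 2 gives 520 nM and compound 3 gives 290 nM; the step of a 1.8-fold lower number from compound 2 to compound 3 (0.25 log units; within the scatter) shows that, on this aromatic carbon, ortho to a large group and meta to a carboxy group, amino can stand in place of nitro with no shift beyond the scatter. In a physicochemical assay for solubility, in simulated intestinal fluid (a lower number here means a less soluble compound, a higher number a more soluble compound), compound 2 gives 112000 nM and compound 3 gives 137000 nM; the same exchange gives a 1.2-fold higher number from compound 2 to compound 3 (0.09 log units; within the scatter), so this read-out also stays within the scatter. In the cGMP-dependent protein kinase 1 assay the step of a 41-fold lower number from compound 1 to compound 3 (1.62 log units; beyond the scatter) is large, which shows that the clear separation from compound 1 survives without the nitro group, with 2-amino-4-carboxyphenyl in the place of 4-carboxy-2-nitrophenyl; no evidence is at hand that explains either this step or the step between the nitro and amino compounds.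

From the compounds shown here alone, it remains open whether a methoxy group, a fluorine atom or a plain hydrogen on this aromatic carbon would also stay within the scatter of these two compounds in the cGMP-dependent protein kinase 1 assay. Also open, going by these compounds, is how an amide in place of the carboxy group would read in the cGMP-dependent protein kinase 1 assay and in the physicochemical assay.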